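Cyano to Amino on the Aromatic Ring of Compound 3

The source may hold more compounds than are shown below. What is called first, only, known or untested is meant among the compounds shown, and "the series" means these compounds.

Measured compounds:
- Compound 1, `N#Cc1ccc(COc2cc3n(n2)CCCC3)nc1`: 316 nM
- Compound 2, `Cc1cccnc1NC(=O)c1cc2n(n1)CCCC2`: "not active" (no number reported)
- Compound 3, `N#Cc1ccc(NC(=O)c2cc3n(n2)CCCC3)nc1`: 90 nM

The measure throughout is a functional assay on HEK293 cells for negative allosteric modulation of metabotropic glutamate receptor 5 (Rattus norvegicus), read by FLIPR and calcium flux, with a stated time of 170 s; a higher number here means a weaker inhibitor, a lower number a stronger inhibitor. Compound 1 gives 316 nM in this assay. Compound 2 was reported in this assay as "not active" (no number reported), without a number. Compound 3 gives 90 nM in this assay and stands lowest of the two numbers; the nearest number is that of compound 1, which lies beyond the usual scatter of this measurement. Within the data shown here, no pair among the measured compounds differs in one place only, so no single step has been isolated.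

The next compound, compound 4, `Nc1ccc(NC(=O)c2cc3n(n2)CCCC3)nc1`, differs from compound 3 in one place: amino in place of cyano on an aromatic carbon. The change removes the cyano that compound 3 carries and introduces an amino there. Among the measured compounds shown here, nothing among the measured compounds shows how this change works, so the expectation rests on the shared core and on where compound 3 stands.

Compound 4 is expected to give 700 nM in this assay, with a range from 150 nM to 3500 nM. This estimate means a step of a 7.8-fold higher number from compound 3 to compound 4 (0.89 log units; beyond the scatter), expected to be a weakening beyond the scatter.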

Compound 4, half-maximal inhibitory concentration: "not active" (no number reported)
No number was reported for compound 4, so the estimate cannot be set against anything.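

Among these compounds, compound 4 was reported in this assay as "not active", without a number, so no step from compound 3 to compound 4 can be read. No measured evidence bears on this result. The compounds shown leave open how large a number compound 4 would have, and so the size of the change from cyano to amino.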